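Adding chloro to compound 1: working notes

The source may report more compounds than this note shows. Statements on the series, on what has been measured and on what is new or still open speak of the compounds shown alone.

- compound 1 `FC(F)(F)c1ccccc1-c1ccc2[nH]c(C3=NOC4(CCCCC4)C3)nc2c1`: 75%
- compound 2 `Fc1ccccc1-c1ccc2[nH]c(C3=NOC4(CCCCC4)C3)nc2c1`: 55%
- compound 3 `FC(F)(F)Oc1ccccc1-c1ccc2[nH]c(C3=NOC4(CCCCC4)C3)nc2c1`: 74%

The numbers come from an ADME assay on microsomes from liver (Rattus norvegicus) for metabolic stability, with a stated time of 10 min; a lower number here means that less of the compound is left, a higher number that more of the compound is left. Compound 1 shares the top of this small set with compound 3, the step being a number 1 percentage points lower from compound 1 to compound 3 (within the scatter). Compound 2 stands clearly lower, with a number 20 percentage points lower from compound 1 to compound 2 (beyond the scatter) and a number 19 percentage points higher from compound 2 to compound 3 (beyond the scatter).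

Compound 4 `FC(F)(F)c1ccccc1-c1cc(Cl)c2[nH]c(C3=NOC4(CCCCC4)C3)nc2c1` differs from compound 1 by chloro in place of hydrogen on an aromatic carbon. The measured steps only exchange fluoro, trifluoromethyl and trifluoromethoxy, so none of them tests this hydrogen. They give a rough size for a single change and no direction. No shift beyond the scatter is expected, and the estimate is a number 3 percentage points lower from compound 1 to compound 4 (within the scatter). For compound 4 the expected value is 72%, with an estimated range of 55% to 88%.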

Compound 4, percent of the compound remaining: 100%
Compound 4: middle estimate off by 28 percentage points, on the low side, and the stated range ends below it.
By their numbers in this assay, from the lowest: compound 2; then compounds 3 and 1 (each within the scatter of the next); then compound 4.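

In this assay, chloro in place of hydrogen on an aromatic carbon ortho to a fused ring gives a number 25 percentage points higher from compound 1 to compound 4 (beyond the scatter), so a change at this position, untouched by the exchanges among fluoro, trifluoromethyl and trifluoromethoxy, can move the read-out beyond the scatter, and upward. Compound 4 reads 100%, the top of this percent scale. Nothing at hand bears on the cause of this step.

From the compounds shown here alone, whether methyl, bromo or an amine at this position would act like chloro stays open. Also open, going by these compounds, is whether chloro gives a similar step with the fluoro or trifluoromethoxy group of compound 2 or compound 3.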